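The source may hold more compounds than are shown below. What is called first, only, known or untested is meant among the compounds shown, and "the series" means these compounds.

Measured so far:
- compound 1, `O=C(Nc1ccc(Br)cc1)N[C@H]1CC[C@H](Oc2ccc(F)cc2)CC1`. In a functional assay on CRL2813 cells (Homo sapiens) for cytotoxicity, read by sulforhodamine B assay, with a stated time of 5 days (a higher number here means a weaker inhibitor, a lower number a stronger inhibitor), compound 1 gives > 20000 nM, which is a limit of the assay rather than a number.
- compound 2, `O=C(Nc1cccc(C(=O)O)c1)N[C@H]1CC[C@H](Oc2ccc(F)cc2)CC1`. In this assay compound 2 gives > 20000 nM, again only a limit.

Compound 2 therefore stands at the top end of what this assay reports, with no number of its own. Within the data shown here, the single step among the measured compounds, a step that the two limits leave unreadable from compound 1 to compound 2, has no readable size because both of its ends are limits (the limit of > 20000 nM in this assay, at which 2 of the 2 values shown sit). Compound 3, `Cc1ccccc1NC(=O)N[C@H]1CC[C@H](Oc2ccc(F)cc2)CC1`, differs from compound 2 by 2-methylphenyl in place of 3-carboxyphenyl on an amide-type nitrogen. Among the measured compounds shown here, only that unreadable step bears on this change, so neither a direction nor a size can be drawn from the measured pair. The step that the limit leaves unreadable from compound 2 to compound 3 is expected to be small or unreadable, most likely leaving compound 3 at the limit as well. Compound 3 is estimated at about 30000 nM, with a range from 6000 nM to 150000 nM.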

Compound 3, half-maximal inhibitory concentration: > 20000 nM
Compound 3: only a limit was reported; the forecaster's own chance of this, stated with the estimate: 75%; the middle value is on the limit's open side.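

Compound 3 gives only a limit of the assay, as do compound 1 and compound 2, so no step among these three compounds can be read: the limit of > 20000 nM in this assay, at which 3 of the 3 values shown sit.

The compounds shown leave open whether any group on the amide-type nitrogen would give a true number in this assay.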